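The source may report more compounds than this note shows. Statements on the series, on what has been measured and on what is new or still open speak of the compounds shown alone.

Compound 1 `COC(=O)c1ccccc1OCc1oc(-c2cccc(OC)c2)nc1C` is the reference point. In an assay on cells for antagonist activity at vitamin D3 receptor (Homo sapiens), read by a luciferase reporter (on this read-out higher numbers stand for weaker inhibition and lower numbers for stronger inhibition), compound 1 gives 15400 nM. Compound 3 `COc1cccc(-c2nc(C)c(COc3ccccc3C(=O)O)o2)c1` carries the change (hydrogen in place of methyl on an oxygen next to a carbonyl group). For compound 3 this assay reports only a limit, > 33000 nM, so no number is known for it. The step of an at least 2.1-fold higher number from compound 1 to compound 3 (0.33 log units; beyond the scatter) therefore rests on one measured number and one limit, and its size is tied to the limit of > 33000 nM in this assay, at which 1 of the 3 values shown sits, the point at which one of the three values shown sits.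

Compound 2 `COC(=O)c1cccc(OCc2oc(-c3ccccc3OC)nc2C)c1` has the same atoms as compound 1 joined differently; the difference between the two cores is not broken down here. In this assay, among the measured compounds shown here, compound 2 gives 7330 nM, the lowest of the two numbers known, with compound 1 the nearest.

Compound 4 `COc1ccccc1-c1nc(C)c(COc2cccc(C(=O)O)c2)o1` is not yet measured. It differs from compound 2 by hydrogen in place of methyl on an oxygen next to a carbonyl group, the same change as that from compound 1 to compound 3, at the same place, on an oxygen next to a carbonyl group whose other neighbour is the carbonyl carbon. For the measured compounds named here, the only measured example of this change is the step from compound 1 to compound 3, which moved the number beyond the scatter towards a limit. On that basis compound 4 is expected to give an at least modest rise in number from compound 2, a 2.5-fold higher number from compound 2 to compound 4 (0.39 log units; beyond the scatter). The estimate for compound 4 in this assay is 18000 nM, with a plausible range from 9000 nM to 33000 nM, and a real chance that only a limit is reported.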

Compound 4, half-maximal inhibitory concentration: > 100000 nM
Compound 4: only a limit was reported (the forecaster's own chance of this, stated with the estimate: 30%); middle value at least 5.5-fold (0.74 log units) from the limit.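

Going from methoxycarbonyl to carboxy weakened inhibition on both cores in this assay, and on the core of compound 2 the new step is an at least 13-fold higher number from compound 2 to compound 4 (1.13 log units; beyond the scatter). Compound 4 is known only through a limit, > 100000 nM. The direction of the change therefore held on the two cores shown, but that is a pattern of only two pairs, and it does not show that the size of the step carries from one core to the other: the same change on two cores in this assay, an at least 2.1-fold higher number (0.33 log units; beyond the scatter) from compound 1 to compound 3 and an at least 13-fold higher number (1.13 log units; beyond the scatter) from compound 2 to compound 4; the limit leaves it open whether they differ

The compounds shown leave open how far inhibition actually falls once the carboxy group is present, as well as which part of the way the two cores are joined matters for the outcome of this change, since the atoms of compound 1 and compound 2 are the same and the difference between their cores is not broken down. They also leave open whether a group other than methoxycarbonyl and carboxy at this place, such as a primary amide, a nitrile or a longer ester like ethoxycarbonyl, would read closer to the methoxycarbonyl compounds or to the carboxy compounds in this assay.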